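Swapping the Aryl Group on an Inactive Compound

The compounds below may be only part of what the source reports. "The series", "measured", "known", "first", "only" and "open" are said of these compounds alone.

Compound 1 `N#CC1=C(N)Oc2c(c3nc4ccccc4nc3c3ccccc23)C12C(=O)N(Cc1cnnn1-c1ccc([N+](=O)[O-])cc1)c1ccccc12` and compound 2 `COc1ccc(-n2nncc2CN2C(=O)C3(C(C#N)=C(N)Oc4c(N)cc5nc6ccccc6nc5c43)c3ccccc32)cc1` share one core and differ in the group carried on an aromatic nitrogen. In a functional assay on MCF7 cells (Homo sapiens) for antiproliferative activity, read by MTT assay, with a stated time of 48 h (a higher number here means a weaker inhibitor, a lower number a stronger inhibitor), compound 1 gives only a limit of > 50000 nM. Compound 2 likewise reaches only a limit of > 50000 nM in this assay. Compound 2 therefore stands at the limit, as the limit of > 50000 nM in this assay, at which 2 of the 2 values shown sit, records. Compound 3 `COc1cc(-n2nncc2CN2C(=O)C3(C(C#N)=C(N)Oc4c(N)cc5nc6ccccc6nc5c43)c3ccccc32)c(OC)cc1Cl` carries 4-chloro-2,5-dimethoxyphenyl in place of 4-methoxyphenyl on an aromatic nitrogen. For the measured compounds named here, no measured step shows what such a change does, so no step beyond the scatter is expected in this assay. Compound 3 is expected to remain at the limit, with an estimated 50000 nM (range 20000 nM to 100000 nM). The step of a number no higher from compound 2 to compound 3 (the limit leaves the size open) is expected to be none beyond the scatter.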

Compound 3, half-maximal inhibitory concentration: > 50000 nM
Compound 3: no number, only a limit (the forecaster's own chance of this, stated with the estimate: 85%); the middle value lies on the limit itself.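

For the compounds shown here, compound 2 and compound 3 each give only a limit in this assay, so no step between them can be read. The compounds shown leave open whether any aryl group at this place on the shared core gives a measurable value.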